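The compounds below may be only part of what the source reports. "The series", "measured", "known", "first", "only" and "open" are said of these compounds alone.

Measured so far in a functional assay on MCF7 cells (Homo sapiens) for cytotoxicity; a higher number here means that more compound is needed for the effect, a lower number that less compound is needed:
compound 1, `COc1cc(Cc2nc3c(N)ncnc3n2CCCO)cc(OC)c1OC`, gives 92700000 nM;
compound 2, `COc1cc(Cc2nc3c(N)ncnc3n2CCCCCO)cc(OC)c1OC`, gives 84900000 nM;
compound 3, `COc1cc(Cc2nc3c(N)ncnc3n2CC(C)CO)cc(OC)c1OC`, gives 49100000 nM.

The three numbers sit close together. Within the data shown here, the steps among them read a 1.1-fold lower number from compound 1 to compound 2 (0.04 log units; within the scatter), a 1.9-fold lower number from compound 1 to compound 3 (0.28 log units; within the scatter) and a 1.7-fold lower number from compound 2 to compound 3 (0.24 log units; within the scatter); none of them separates one compound from another, so no ordering within the set is claimed and no compound is singled out.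

Compound 4, `COc1cc(Cc2nc3c(N)ncnc3n2CC(C)CCCO)cc(OC)c1OC`, has not yet been measured in this assay. It differs from compound 3 by 2-hydroxyethyl in place of hydroxy on a saturated chain carbon, three bonds along the chain from an aromatic nitrogen. The same change has been made once already in the set, from compound 1 to compound 2, as 2-hydroxyethyl in place of hydroxy on a saturated chain carbon, three bonds along the chain from an aromatic nitrogen, and there it gave a 1.1-fold lower number from compound 1 to compound 2 (0.04 log units; within the scatter). The cores on which the change is made differ by methyl in place of hydrogen on a saturated chain carbon bound to two saturated chain carbons. The place of the change reads the same word for word in both pairs, so it is the same change, carried out on the core of compound 3 rather than on that of compound 1.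

On that single precedent the step is expected to be a 1.1-fold lower number from compound 3 to compound 4 (0.04 log units; within the scatter), set against the earlier 1.1-fold lower number from compound 1 to compound 2 (0.04 log units; within the scatter), and it is expected to stay small because the earlier step was a 1.1-fold lower number from compound 1 to compound 2 (0.04 log units; within the scatter). One prior example in a noisy assay is thin ground, so the range is kept wide. Compound 4 is estimated at 45000000 nM, expected to fall from 20000000 nM to 100000000 nM.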

Compound 4, half-maximal effective concentration: 8770000 nM
Beside the measured number, compound 4's estimate is 5.1-fold (0.71 log units) above it; measured number outside the range, below it.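

In this assay, 2-hydroxyethyl in place of hydroxy gives a 5.6-fold lower number from compound 3 to compound 4 (0.75 log units; beyond the scatter), so this change does not carry over at the same size from one core to the other: the same change on two cores in this assay, a 1.1-fold lower number (0.04 log units; within the scatter) from compound 1 to compound 2 and a 5.6-fold lower number (0.75 log units; beyond the scatter) from compound 3 to compound 4, 5.1-fold (0.71 log units) apart, beyond the scatter of two such steps

Read from the other side of the same four compounds, methyl in place of hydrogen gives a 9.7-fold lower number from compound 2 to compound 4 (0.99 log units; beyond the scatter), and it too differs from its earlier step: the same change on two cores in this assay, a 1.9-fold lower number (0.28 log units; within the scatter) from compound 1 to compound 3 and a 9.7-fold lower number (0.99 log units; beyond the scatter) from compound 2 to compound 4, 5.1-fold (0.71 log units) apart, beyond the scatter of two such steps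

Taken together, the two changes give an 11-fold lower number from compound 1 to compound 4 (1.02 log units; beyond the scatter), and compound 4 stands apart from the other three, so in this set the two changes do not behave as independent increments; this rests on one set of four compounds, however, and shows neither a rule for other cores nor why the steps differ.

From the compounds shown here alone, it remains open whether the lower number is particular to the 4-hydroxy-1-methylbutyl chain or would also appear with a longer chain, or with an amine or a carboxylic acid in place of hydroxy. Going by these compounds, it is also open whether the same dependence on the core would appear outside this assay, since all the numbers here come from that one assay.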